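The source may report more compounds than this note shows. Statements on the series, on what has been measured and on what is new or still open speak of the compounds shown alone.

Of the compounds shown here, two have been tested in a functional assay on CCRF-CEM cells (Homo sapiens) for cytotoxicity; on this read-out higher numbers stand for lower toxicity in this test and lower numbers for higher toxicity in this test. Compound 1 `O=c1[nH]c(=S)[nH]c2c(CCCCCOCc3ccccc3)ncn12` gives 259000 nM in this assay. Compound 2 `Cc1ccc(Cc2ncn3c(O)ncnc23)cc1` reaches only the limit of this assay, > 833000 nM, so no number is known for it. On the numbers shown, compound 2 stands at the limit of > 833000 nM in this assay, at which 1 of the 2 values shown sits, while compound 1 sits below it with a measured value. Compound 3 `Cc1ccc(Cc2ncn3c(N(C)C)ncnc23)cc1` is the next compound to be measured; its change from compound 2 is dimethylamino in place of hydroxy on an aromatic carbon. Among the measured compounds shown here, no step between two measured compounds is available, so the size of such a change cannot be read from any measured pair. The expectation for compound 3 is a step of an at least 1.1-fold lower number from compound 2 to compound 3 (0.07 log units; that floor lies within the scatter) that stays within the usual scatter of this assay. Compound 3 is therefore estimated at 700000 nM, with a range from 250000 nM to 2000000 nM, and a real chance that only a limit is reported again.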

Compound 3, half-maximal cytotoxic concentration: 412000 nM
Estimate against measurement, compound 3: 1.7-fold (0.23 log units) above; measured number inside the range.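

Placing dimethylamino in place of hydroxy on an aromatic carbon, between two ring nitrogen atoms, gives the first step that can be read at this position: an at least 2.0-fold lower number from compound 2 to compound 3 (0.30 log units; that floor lies within the scatter). This shows that a number can be obtained in this assay with dimethylamino at this place, but the floor of the step does not by itself establish a real change in toxicity. Compound 2 has only a limit, so the step has a floor but no known full size: the limit of > 833000 nM in this assay, at which 1 of the 3 values shown sits.

Going by these compounds, it remains open how a plain amino group or a methoxy group at this same place would read in this assay. Compound 1 differs from compound 2 and compound 3 in more than one place, so it cannot show how its longer chain contributes.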